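Swapping dichloro for difluoro on the aryl ketone

This account rests on a few compounds, and the source may have more. Where it says the series, first, only, none or still open, it means among the compounds named here.

Of the compounds shown here, three have so far been measured. Compound 1 `COc1ccc(-c2cc(/C=C/C(=O)c3ccc(N)cc3)[nH]n2)cc1` gives 1740 nM in a functional assay on BT-549 cells (Homo sapiens) for inhibition, read by sulforhodamine B assay, with a stated time of 48 h; on this read-out higher numbers stand for weaker inhibition of growth and lower numbers for stronger inhibition of growth. Compound 2 `COc1cc(-c2cc(/C=C/C(=O)c3ccc(Cl)c(Cl)c3)[nH]n2)cc(OC)c1OC` gives 8400 nM in this assay, the highest number of the three and above both of the others beyond the scatter. Among the compounds with values here, compound 3 `COc1ccc(C(=O)/C=C/c2cc(-c3cc(OC)c(OC)c(OC)c3)n[nH]2)cc1OC` gives 1440 nM in this assay, and the one single-point step on record, a 5.8-fold lower number from compound 2 to compound 3 (0.77 log units; beyond the scatter), is the only measured change at the carbonyl aryl group.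

Compound 4 `COc1cc(-c2cc(/C=C/C(=O)c3ccc(F)c(F)c3)[nH]n2)cc(OC)c1OC` has not yet been measured. It differs from compound 2 in one place: 3,4-difluorophenyl in place of 3,4-dichlorophenyl on a carbonyl carbon. Within the data shown here, no measured step exchanges one halogenated aryl group for another, so the step to compound 3 bears on it only loosely, as a sign that this position can move the number by a modest amount. With the two halogens retained in the same pattern, compound 4 is expected to stay close to compound 2, the step of a 1.4-fold lower number from compound 2 to compound 4 (0.15 log units; within the scatter) being estimated to lie within or only just beyond the scatter. Compound 4 is therefore expected to give about 6000 nM, with a range from 2000 nM to 18000 nM.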

Compound 4, concentration for 50% growth inhibition: 4110 nM
Compound 4: the middle estimate sits 1.5-fold (0.16 log units) above what was measured; measured number inside the range.
By their numbers in this assay, from the lowest: compounds 3 and 1 (each within the scatter of the next); then compound 4; then compound 2.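

In this assay, the carbonyl aryl group now has three measured forms on an otherwise shared structure, and even exchanging one halogen pair for the other moves the number, with a 2.0-fold lower number from compound 2 to compound 4 (0.31 log units; beyond the scatter). The 3,4-difluorophenyl group still does not match the 3,4-dimethoxyphenyl group, with a 2.9-fold higher number from compound 3 to compound 4 (0.46 log units; beyond the scatter), so all three groups at this position are separated beyond the scatter, and compound 4 lies between compound 3 and compound 2. Nothing on hand explains this order.

The compounds shown leave open how a trifluoromethyl, a nitrile or a carboxylic acid on this aryl group would stand against these three. They also leave open whether the same order holds when the rest of the structure is changed.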